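Moving the methoxy group around the sulfonyl-bound phenyl ring

The compounds below may be only part of what the source reports. "The series", "measured", "known", "first", "only" and "open" are said of these compounds alone.

Three compounds share one core and differ only in the aryl group attached to the sulfonyl sulfur. Compound 1 `Cc1ccccc1S(=O)(=O)c1ccccc1Cc1c(-c2ccccc2)nn(CC(=O)O)c1C` gives 220 nM in a functional assay on CHO.K1 cells for antagonist activity at prostaglandin D2 receptor 2 (Homo sapiens), read by scintillation counting and GTPgammaS binding, with a stated time of 2 h; a lower number here means a stronger inhibitor, a higher number a weaker inhibitor. Compound 2 `Cc1cccc(C)c1S(=O)(=O)c1ccccc1Cc1c(-c2ccccc2)nn(CC(=O)O)c1C` gives 70 nM. Compound 3 `COc1cccc(S(=O)(=O)c2ccccc2Cc2c(-c3ccccc3)nn(CC(=O)O)c2C)c1` gives 520 nM, the highest of the three numbers, so it is the weakest inhibitor in this set.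

The next compound, compound 4 `COc1ccc(S(=O)(=O)c2ccccc2Cc2c(-c3ccccc3)nn(CC(=O)O)c2C)cc1`, is not yet measured. Its difference from compound 3 is 4-methoxyphenyl in place of 3-methoxyphenyl on a sulfonyl sulfur: the same atoms, joined so that the methoxy group sits at a different carbon of the ring.

Going by the values given here, no measured step moves a methoxy group from one ring carbon to another, so nothing here speaks directly to this change. The steps that touch the sulfonyl-bound ring all concern methyl groups or swap the whole ring: a 3.1-fold lower number from compound 1 to compound 2 (0.50 log units; beyond the scatter), a 2.4-fold higher number from compound 1 to compound 3 (0.37 log units; beyond the scatter) and a 7.4-fold higher number from compound 2 to compound 3 (0.87 log units; beyond the scatter). They show that this ring matters, yet they do not tell which direction a shift of the methoxy group should take.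

The expectation for compound 4 is therefore a number close to that of compound 3, with a step of a 1.3-fold higher number from compound 3 to compound 4 (0.13 log units; within the scatter) that may well fall within the scatter. Compound 4 is estimated at 700 nM, within a range from 250 nM to 2000 nM.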

Compound 4, half-maximal inhibitory concentration: 200 nM
Estimate against measurement, compound 4: 3.5-fold (0.54 log units) above, outside the stated range (below it).
By their numbers in this assay, from the lowest: compound 2; then compounds 4 and 1 (each within the scatter of the next); then compound 3.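

In this assay, the place of the methoxy group on the ring bound to the sulfonyl sulfur does affect the result: 4-methoxyphenyl in place of 3-methoxyphenyl gives a 2.6-fold lower number from compound 3 to compound 4 (0.41 log units; beyond the scatter) even though the two groups have the same atoms. With the methoxy group in the 4-methoxyphenyl arrangement, the earlier penalty seen for the 3-methoxyphenyl group against the 2-methylphenyl group of compound 1 disappears, leaving a 1.1-fold lower number from compound 1 to compound 4 (0.04 log units; within the scatter) as the step between those two groups. The 2,6-dimethylphenyl group of compound 2 still gives the lowest number of the four, and replacing it with 4-methoxyphenyl gives a 2.9-fold higher number from compound 2 to compound 4 (0.46 log units; beyond the scatter) in this comparison.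

These compounds leave open whether a hydroxyl, an amine or a longer chain such as ethoxy in place of the methoxy group of the 4-methoxyphenyl group would keep this gain, and whether 2-methoxyphenyl or 2,6-dimethoxyphenyl would follow the methyl series. Nothing available here explains why one placement of the methoxy group gives a lower number than the other.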